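The source may report more compounds than this note shows. Statements on the series, on what has been measured and on what is new or still open speak of the compounds shown alone.

Compounds 1 and 2 share one core and differ at the amide end. Compound 1 `CCCCc1oc2ccccc2c1C(=O)c1ccc(OCC(=O)N2CCOCC2)cc1` and compound 2 `CCCCc1oc2ccccc2c1C(=O)c1ccc(OCC(=O)NCc2ccccc2)cc1` are separated by benzylamino in place of morpholin-4-yl on a carbonyl carbon. In a functional assay on MDA-MB-231 cells (Homo sapiens) for antiproliferative activity, read by MTT assay, with a stated time of 24 h (a lower number here means a stronger inhibitor, a higher number a weaker inhibitor), compound 1 gives > 50000 nM, which is a limit of the assay and not a number. In this assay compound 2 gives > 50000 nM, again a limit. The step that the two limits leave unreadable from compound 1 to compound 2 therefore has no readable size, a consequence of the limit of > 50000 nM in this assay, at which 2 of the 3 values shown sit.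

Compound 3 `CCCCc1oc2ccccc2c1C(=O)c1ccc(OCCCC(=O)N2CCOCC2)cc1` carries a longer chain than compound 1; the two cores differ by 2-((morpholin-4-yl)carbonyl)ethyl in place of (morpholin-4-yl)carbonyl on a saturated chain carbon bound to an oxygen on an aromatic ring. In this assay, among the compounds with values here, compound 3 gives 31600 nM, the only number among the three. The steps of an at least 1.5-fold lower number from compound 1 to compound 3 (0.19 log units; that floor lies within the scatter) and an at least 1.5-fold lower number from compound 2 to compound 3 (0.19 log units; that floor lies within the scatter) are floors only.

Compound 4 `CCCCc1oc2ccccc2c1C(=O)c1ccc(OCCCC(=O)NCc2ccccc2)cc1` remains to be measured. It differs from compound 3 by benzylamino in place of morpholin-4-yl on a carbonyl carbon, the same change as from compound 1 to compound 2, at a place described in the same words. The expectation rests on compound 3 at 31600 nM and on the earlier unreadable step. The step in this assay is expected to be a 1.1-fold higher number from compound 3 to compound 4 (0.04 log units; within the scatter). Compound 4 is expected to give about 35000 nM, between 12000 nM and 100000 nM.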

Compound 4, half-maximal inhibitory concentration: > 50000 nM
Compound 4: a limit, no number; the forecaster's own chance of this, stated with the estimate: 40%; middle value at least 1.4-fold (0.15 log units) away from the limit.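

In this assay compound 4 gives > 50000 nM as a limit of the assay and not a number. Benzylamino in place of morpholin-4-yl on a carbonyl carbon therefore gives an at least 1.5-fold higher number from compound 3 to compound 4 (0.19 log units; that floor lies within the scatter) on the core of compound 3, a floor only, while the same change on the core of compound 1 cannot be read, so the series shows no readable size of this change on either core and cannot say whether the size carries from one core to the other. What carries over is only this: on both cores the compound with benzylamino sits at a limit, and the reading stops there: the limit of > 50000 nM in this assay, at which 3 of the 4 values shown sit.

The compounds shown leave open whether another amine on the same carbonyl carbon, such as piperidin-1-yl or dimethylamino, would give a number on the core of compound 3. From the compounds shown here alone, whether a carboxylic acid in place of the amide, or a longer chain than that of compound 3, would lower the number in this assay also stays open.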